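Cyano on the Pyrazole of Fatty-Acid Amide Hydrolase Inhibitors

The source may report more compounds than this note shows. Statements on the series, on what has been measured and on what is new or still open speak of the compounds shown alone.

Measured compounds:
- compound 1, `O=C(N1CCCN(Cc2ccc(OCc3ccccc3)cc2)CC1)n1cccn1`, 450 nM
- compound 2, `N#Cc1cnn(C(=O)N2CCCN(Cc3ccc(OCc4ccccc4)cc3)CC2)c1`, < 10 nM
- compound 3, `CN(CCN(C)C(c1ccc(OCc2ccccc2)cc1)c1ccc(OCc2ccccc2)cc1)C(=O)n1cccn1`, > 1000000 nM

All three were tested in an assay on membranes from brain for binding affinity to Fatty-acid amide hydrolase 1 (Mus musculus), read by fluorescence, with stated times of 1 h and 30 min; on this read-out higher numbers stand for weaker inhibition and lower numbers for stronger inhibition. Compound 1 gives 450 nM. Compound 2 differs from it only by cyano in place of hydrogen on an aromatic carbon, and the step is an at least 45-fold lower number from compound 1 to compound 2 (1.65 log units; beyond the scatter). The value of compound 2 is a limit of this assay, not a number, as given by the limit of < 10 nM in this assay, at which 1 of the 3 values shown sits, so the true size of this step is not known beyond its lower bound.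

Compound 3 has a different core. Its value in this assay is also a limit, (the limit of > 1000000 nM in this assay, at which 1 of the 3 values shown sits), and no number is available for it. The difference between the core of compound 3 and the core of compound 1 is not broken down here.

Compound 4, `CN(CCN(C)C(c1ccc(OCc2ccccc2)cc1)c1ccc(OCc2ccccc2)cc1)C(=O)n1cc(C#N)cn1`, has not yet been measured. For the measured compounds named here, it differs from compound 3 by cyano in place of hydrogen on an aromatic carbon, which is the same kind of change as the one from compound 1 to compound 2, and the place described is the same word for word.

Because the step of an at least 45-fold lower number from compound 1 to compound 2 (1.65 log units; beyond the scatter) was large, a lowering is expected for compound 4 as well, so the estimated step is an at least 10-fold lower number from compound 3 to compound 4 (1.00 log units; beyond the scatter). Since compound 3 sits at a limit of this assay, this expectation is uncertain, and the estimate for compound 4 is 100000 nM, between 2000 nM and 1000000 nM.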

Compound 4, half-maximal inhibitory concentration: > 1000000 nM
Compound 4 ended at the assay's limit; the forecaster's own chance of this, stated with the estimate: 50%; middle value at least 10-fold (1.00 log units) away from the limit.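

In this assay compound 4 gives > 1000000 nM as a limit of the assay, not a number. Compound 3 gives > 1000000 nM as a limit too. For the compounds shown here, no step from compound 3 to compound 4 can be read, with both at the same limit: the limit of > 1000000 nM in this assay, at which 2 of the 4 values shown sit.

The compounds shown leave open whether cyano in place of hydrogen on an aromatic carbon changes inhibition at all on the core of compound 3.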